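Longer alkyl chain on a sulfonamide series with no measured steps

The source may hold more compounds than are shown below. What is called first, only, known or untested is meant among the compounds shown, and "the series" means these compounds.

Three compounds share one core, a sulfonamide linking two aromatic rings, one of which carries a cyclic urea. Compound 1 `CC(C)Cc1ccc(NS(=O)(=O)c2ccc(N3CCNC3=O)cc2)cc1` carries an isobutyl group on the outer ring. In a functional assay on HT-29 cells (Homo sapiens) for antiproliferative activity, read by sulforhodamine B assay, with a stated time of 48 h (a higher number here means a weaker inhibitor, a lower number a stronger inhibitor), compound 1 gives only a limit, > 1000 nM. Compound 1 therefore stands at the limit of > 1000 nM in this assay, at which 2 of the 3 values shown sit. Compound 2 `CC(C)(C)c1cc(NS(=O)(=O)c2ccc(N3CCNC3=O)cc2)cc(C(C)(C)C)c1` carries two tert-butyl groups on that ring, and in this assay compound 2 also reaches only a limit, > 1000 nM. Compound 3 `Cc1ccc(C)c(NS(=O)(=O)c2ccc(N3CCNC3=O)cc2)c1` carries two methyl groups instead, and in this assay compound 3 gives 46 nM, a genuine number.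

Compound 4 `CCCCCCCc1ccc(NS(=O)(=O)c2ccc(N3CCNC3=O)cc2)cc1` is not yet measured. It differs from compound 1 in one place: hexyl in place of isopropyl on a saturated chain carbon bound to an aromatic carbon. Among the measured compounds shown here, no measured pair differs in a single place, so the size of such a step is not known from these data. The step that the limit leaves unreadable from compound 1 to compound 4 is expected to be none beyond the scatter, leaving compound 4 at a limit too. Compound 4 is estimated at 3000 nM, between 800 nM and 20000 nM.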

Compound 4, half-maximal inhibitory concentration: > 1000 nM
Compound 4: no number, only a limit (the forecaster's own chance of this, stated with the estimate: 70%); the middle value does not contradict the limit.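

Among the compounds shown here, compound 1 and compound 4 both give only a limit, so no step between them can be read: the limit of > 1000 nM in this assay, at which 3 of the 4 values shown sit.

In this assay the compounds shown leave open whether heptyl in place of isobutyl changes activity at all.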